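Trimethoxyphenyl pyrazole chalcones: a fluorinated analogue awaits measurement

The source may hold more compounds than are shown below. What is called first, only, known or untested is meant among the compounds shown, and "the series" means these compounds.

Measured compounds:
compound 1, `COc1cc(-c2cc(/C=C/C(=O)c3ccc(N)cc3)[nH]n2)cc(OC)c1OC`, 7530 nM
compound 2, `COc1cc(C(=O)/C=C/c2cc(-c3cc(OC)c(OC)c(OC)c3)n[nH]2)cc(OC)c1OC`, 4040 nM

Of the compounds shown here, two that share a trimethoxyphenyl pyrazole core have so far been tested in a functional assay on SK-MEL-2 cells (Homo sapiens) for inhibition, read by sulforhodamine B assay, with a stated time of 48 h; on this read-out lower numbers stand for stronger inhibition of growth and higher numbers for weaker inhibition of growth. Compound 1 gives 7530 nM, and compound 2 gives 4040 nM. The gap between these two numbers lies within the scatter of the method, so the two compounds are not distinguished from each other by this measurement; compound 1 simply has the higher of the two numbers.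

Compound 3, `COc1cc(-c2cc(/C=C/C(=O)c3ccc(F)c(F)c3)[nH]n2)cc(OC)c1OC`, has not yet been measured in this assay. Relative to compound 1 it carries 3,4-difluorophenyl in place of 4-aminophenyl on a carbonyl carbon. Among the measured compounds shown here, no measured pair shows the effect of such a change, so the expectation rests on compound 1 alone. The step of a 1.3-fold higher number from compound 1 to compound 3 (0.12 log units; within the scatter) is expected to be modest, going toward a somewhat higher number, and may well stay within the scatter. Compound 3 is therefore estimated to give 10000 nM, with a range from 3000 nM to 30000 nM.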

Compound 3, concentration for total growth inhibition: 5890 nM
For compound 3 the middle estimate is 1.7-fold (0.23 log units) above the measured one; the measured number falls inside the stated range.
By their numbers in this assay, from the lowest: compounds 2, 3 and 1 (each within the scatter of the next).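

Among the compounds shown here, the step of a 1.3-fold lower number from compound 1 to compound 3 (0.11 log units; within the scatter) is the first measured change on this carbonyl carbon, and in this assay it stays within the scatter. The 4-aminophenyl group counts one hydrogen-bond donor and one hydrogen-bond acceptor and the 3,4-difluorophenyl group counts neither, yet this read-out does not separate compound 1 from compound 3, so this single pair gives no sign that the amino group is required at this place for the measured inhibition of growth. Nothing measured among the data shown explains this outcome.

The compounds shown leave open whether any other group on this carbonyl carbon, such as a 4-carboxyphenyl, a 4-methoxyphenyl, a pyridine ring or a plain unsubstituted phenyl, would give a step beyond the scatter. They also leave open whether a single fluorine or a trifluoromethyl on the same phenyl ring would behave like the 3,4-difluorophenyl group, and whether the result would hold on a core carrying a methyl group on the pyrazole nitrogen.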